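A few compounds are considered here, and "the series" means these few. Any claim that something is new, unique, unknown or untested is made for them only; others in the source may bear on it.

The series shares one core, seen in compound 1 `O=C(O)CC/C=C\CO[C@H]1[C@@H](OCc2ccc(-c3ccccc3CO)cc2)CC[C@@H]1N1CCCCCC1`, compound 2 `O=C(O)CC/C=C\CO[C@H]1C(OCc2ccc(-c3ccccc3)cc2)CC[C@@H]1N1CCCCC1` and compound 3 `CS(=O)(=O)Nc1cccc(-c2ccc(COC3CC[C@H](N4CCCCCC4)[C@H]3OC/C=C\CCC(=O)O)cc2)c1`. In a functional assay for antagonist activity at thromboxane A2 receptor (Rattus norvegicus) (a higher number here means weaker binding, a lower number tighter binding), compound 1 gives 12.6 nM, the lowest of the two single numbers, while compound 3 gives 50.1 nM, a gap beyond the scatter. Compound 2 gives 794 nM; 63.1 nM (2 entries), two entries far apart (the several entries of compound 2 in this assay, 794 nM; 63.1 nM (2 entries)), so it offers no single number to compare. Compound 4 `CS(=O)(=O)Nc1ccccc1-c1ccc(CO[C@H]2CC[C@H](N3CCCCCC3)[C@H]2OC/C=C\CCC(=O)O)cc1` is compound 1 with one change: methanesulfonamido in place of hydroxymethyl on an aromatic carbon. Within the data shown here, no pair of measured compounds differs by just this change, so the size of the step can only be expected. Compound 4 is expected to lose a little, by a 2.0-fold higher number from compound 1 to compound 4 (0.30 log units; within the scatter), a step near the edge of the scatter. The estimate for compound 4 is 25 nM, with a range from 8 nM to 80 nM.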

Compound 4, dissociation constant: 63.1 nM
Beside the measured number, compound 4's estimate is 2.5-fold (0.40 log units) below it; measured number inside the range.
By their numbers in this assay, from the lowest: compound 1; then compounds 3 and 4 (each within the scatter of the next).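

Among these compounds, the first measured step at this position, on an aromatic carbon ortho to a large group, is a 5.0-fold higher number from compound 1 to compound 4 (0.70 log units; beyond the scatter) in this assay. Methanesulfonamido therefore does not match hydroxymethyl here, although the loss stays modest. Its exact size calls for some caution, as entries for one compound can lie far apart in this assay: the several entries of compound 2 in this assay, 794 nM; 63.1 nM (2 entries)

The compounds shown leave open how an amine or a carboxylic acid would compare on this carbon. They also leave open whether a longer chain carrying the hydroxyl would keep the number of compound 1, 12.6 nM.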